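Acylation of the ring nitrogen in the series

The compounds below may be only part of what the source reports. "The series", "measured", "known", "first", "only" and "open" are said of these compounds alone.

Measured compounds:
compound 1 `COc1cc(/C=C/C(=O)c2cccc(NC(=O)c3ccc(Cl)cc3)c2)ccc1O` — 66%
compound 2 `COc1cc(/C=C/C(=O)c2cccc(N)c2)ccc1O` — 90%
compound 3 `COc1cc(/C=C/C(=O)c2cccc(NC(=O)C(C)C)c2)ccc1O` — 56%

In a functional assay on HUVEC cells (Homo sapiens) for inhibition, tested at 10 ug/mL (on this read-out lower numbers stand for a weaker effect and higher numbers for a stronger effect at the one concentration tested), compound 2 gives the highest of the three numbers. Its nearest neighbour is compound 1, the gap being a number 24 percentage points higher from compound 1 to compound 2 (beyond the scatter); the furthest is compound 3, the gap being a number 34 percentage points lower from compound 2 to compound 3 (beyond the scatter). Both gaps lie beyond the scatter, so compound 2 is the strongest of the three on this read-out.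

Compound 4 `CCOC(=O)C(=O)Nc1cccc(C(=O)/C=C/c2ccc(O)c(OC)c2)c1` is still to be measured. It differs from compound 2 by (ethoxycarbonyl)carbonyl in place of hydrogen on a nitrogen on an aromatic ring. The two steps that bear on this change are the two acylations of the same ring nitrogen already seen: a number 34 percentage points lower from compound 2 to compound 3 (beyond the scatter) and, read in reverse, a number 24 percentage points higher from compound 1 to compound 2 (beyond the scatter). Both lower the number beyond the scatter. The two acyl groups themselves differ by a number 10 percentage points lower from compound 1 to compound 3 (within the scatter), which lies within the scatter, so the size of the acyl group has not yet shown a separate effect. A third acyl group on the same nitrogen is therefore expected to lower the number by a comparable amount, a number 30 percentage points lower from compound 2 to compound 4 (beyond the scatter). For compound 4 the expected value in this assay is 60%, within a range of 40% to 80%.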

Compound 4, a percentage reported as inhibition, at one concentration (the size of the read-out at that concentration, not a potency): 66%
The estimate for compound 4 lay 6 percentage points below the measured number; the range from low to high includes it.
By their numbers in this assay, from the lowest: compounds 3, 1 and 4 (each within the scatter of the next); then compound 2.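

In this assay a third acyl group on the ring nitrogen again gives a step beyond the scatter, a number 24 percentage points lower from compound 2 to compound 4 (beyond the scatter), so compound 2, with its free amino group, now stands apart from all three acylated compounds. This holds for (ethoxycarbonyl)carbonyl, which carries 3 hydrogen-bond acceptors and no ring, as well as for the isopropyl and 4-chlorophenyl amides. Among the acylated compounds, the steps are a number 10 percentage points higher from compound 3 to compound 4 (within the scatter) and no change at the digits printed from compound 1 to compound 4 (within the scatter), so ethoxycarbonyl on the carbonyl carbon cannot be told apart from isopropyl or 4-chlorophenyl on this read-out.

No available measurement accounts for the gap between the free amino compound and the acylated compounds. Still open, on these data alone, is whether any substituent on this nitrogen gives the same step or only an acyl group does, which a methyl group or a methanesulfonyl group in place of the hydrogen could test, and the single concentration leaves the potency of all these compounds unknown.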